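A few compounds are considered here, and "the series" means these few. Any claim that something is new, unique, unknown or untested is made for them only; others in the source may bear on it.

Of the compounds shown here, two have so far been measured in a functional assay on HUVEC cells (Homo sapiens) for inhibition, read by MTT assay, with a stated time of 24 h, tested at 10 uM; on this read-out lower numbers stand for less inhibition of growth and higher numbers for more inhibition of growth at the one concentration tested. Compound 1 `COc1cc2ccc(=O)oc2cc1OCC(O)CN1CCN(C)CC1` gives 0.1% there, while compound 2 `COc1cc2ccc(=O)oc2cc1OCCCCBr` gives 11.2%. Compound 2 thus stands highest of the two numbers; its nearest neighbour is compound 1, whose value lies lower by a gap beyond the scatter of repeated measurements. Going by the values given here, no step between the two measured compounds has been worked out, since they differ in more than one place. Compound 3 `COc1cc2ccc(=O)oc2cc1OCCNC(C)C` has not yet been measured in this assay. It differs from compound 2 by isopropylamino in place of 2-bromoethyl on a saturated chain carbon, two bonds along the chain from an oxygen on an aromatic ring. Compound 1 gives 0.1%, the lower of the two numbers, and compound 3 is expected to move in that direction, by a modest step that may still lie within the scatter. The step is estimated as a number 7.2 percentage points lower from compound 2 to compound 3 (within the scatter). Compound 3 is therefore estimated at 4%, with a range from -4% to 13%.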

Compound 3, percent growth inhibition at one concentration: 0.1%
Beside the measured number, compound 3's estimate is 3.9 percentage points above it; measured number inside the range.
By their numbers in this assay, from the lowest: compounds 1 and 3 (each within the scatter of the next); then compound 2.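

Going by these compounds alone, at this position, on a saturated chain carbon, two bonds along the chain from an oxygen on an aromatic ring, replacing 2-bromoethyl with isopropylamino gives the first step that can be read in this assay: a number 11.1 percentage points lower from compound 2 to compound 3 (beyond the scatter). Cut one bond further out, the same change reads 4-bromobutyl to 2-(isopropylamino)ethyl, and within this single pair the bromobutyl chain carries the higher number. Nothing available bears on why the number changes with this exchange.

The compounds shown leave open whether the step follows from losing the bromine or from gaining the amine, a question that a 4-chlorobutyl or plain butyl chain would address. They also leave open whether a different amine at the chain end, such as dimethylamino or morpholine, would read the same way.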